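Moving the chlorine on the pendant ring: compound 2 to compound 4

The source may report more compounds than this note shows. Statements on the series, on what has been measured and on what is new or still open speak of the compounds shown alone.

Measured compounds:
- Compound 1, `Cc1c(/N=C/c2ccc(N(C)C)cc2)c(=O)n(-c2ccccc2)n1C`: 832000000 nM
- Compound 2, `Cc1c(/N=C/c2ccccc2Cl)c(=O)n(-c2ccccc2)n1C`: 851000000 nM
- Compound 3, `COc1ccc(/C=N/c2c(C)n(C)n(-c3ccccc3)c2=O)cc1OC`: 575000000 nM

All three compounds were tested in a functional assay on HCT-116 cells (Homo sapiens) for cytotoxicity, read by MTT assay, with a stated time of 72 h; a higher number here means a weaker inhibitor, a lower number a stronger inhibitor. Compound 2 gives the highest of the three numbers, but its gap to compound 1 and its gap to compound 3 both lie within the scatter of repeated measurements, so no order among them can be read. Compound 4, `Cc1c(/N=C/c2ccc(Cl)cc2)c(=O)n(-c2ccccc2)n1C`, has not yet been measured. It differs from compound 2 in one place: 4-chlorophenyl in place of 2-chlorophenyl on a carbon with a double bond to nitrogen. For the measured compounds named here, no measured pair in this set differs in a single place, so there is no step to lean on. Given that compound 1, compound 2 and compound 3 all give numbers within the scatter of one another in this assay despite differing pendant rings, compound 4 is expected to behave much the same, with a step of a 1.1-fold lower number from compound 2 to compound 4 (0.03 log units; within the scatter) that is not beyond the scatter. Compound 4 is therefore estimated at 800000000 nM, with a range from 400000000 nM to 1600000000 nM.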

Compound 4, half-maximal inhibitory concentration: 589000000 nM
Compound 4: middle estimate off by 1.4-fold (0.13 log units), on the high side, and the stated range covers the measured number.
By their numbers in this assay, from the lowest: compounds 3, 4, 1 and 2 (each within the scatter of the next).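

In this assay moving the chlorine, with 4-chlorophenyl in place of 2-chlorophenyl on a carbon with a double bond to nitrogen, gives a 1.4-fold lower number from compound 2 to compound 4 (0.16 log units; within the scatter) and so no readable change. For the compounds shown here, compound 4 also gives the first comparison at this place with a group other than chloro: chloro in place of dimethylamino on an aromatic carbon gives a 1.4-fold lower number from compound 1 to compound 4 (0.15 log units; within the scatter) and, again, no readable change. Nothing measured here accounts for either result.

The compounds shown leave open whether a carboxylic acid, a primary amine or a longer alkyl chain on the pendant ring would give a number beyond the scatter of these four. Going by these compounds, all four share one core, so what a change to that core would do also remains open.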